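The source may hold more compounds than are shown below. What is called first, only, known or untested is meant among the compounds shown, and "the series" means these compounds.

Compound 2, `Cc1ccc2[nH]c(C(=O)N[C@H]3CN(S(=O)(=O)c4ccccc4)C[C@@H]3C(=O)N[C@H]3CCCNC3)cc2c1`: in an ADME assay on Caco-2 cells (Homo sapiens) for permeability, in the apical to basolateral direction, at pH 7.4 (on this read-out higher numbers stand for higher permeability and lower numbers for lower permeability), compound 2 gives 0.04 10^-6 cm/s.
Compound 1, `Cc1ccc2[nH]c(C(=O)N[C@H]3CN(S(=O)(=O)c4ccccc4)C[C@@H]3C(=O)NC[C@H]3CCCN3)cc2c1`: in this assay compound 1 gives 0.11 10^-6 cm/s.

Compound 2 stands lowest of these two numbers, with compound 1 giving the higher one, a change of a 2.8-fold lower number from compound 1 to compound 2 (0.44 log units; beyond the scatter). Compound 3, `O=C(N[C@H]1CN(S(=O)(=O)c2ccccc2)C[C@@H]1C(=O)N[C@H]1CCCNC1)c1cn(C2CC2)cn1`, keeps the rest of compound 2 and differs by 1-cyclopropyl-1H-imidazol-4-yl in place of 5-methyl-1H-indol-2-yl on a carbonyl carbon. Within the data shown here, the only measured step concerns another place on the molecule, so nothing measured bears directly on this change. The expected step of a 1.5-fold higher number from compound 2 to compound 3 (0.18 log units; within the scatter) is therefore uncertain and could sit within the scatter. Compound 3 is estimated at 0.06 10^-6 cm/s, between 0.02 10^-6 cm/s and 0.2 10^-6 cm/s.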

Compound 3, apparent permeability: 0.48 10^-6 cm/s
Compound 3: the middle estimate sits 8.0-fold (0.90 log units) below what was measured; measured number outside the range, above it.
By their numbers in this assay, from the lowest: compound 2; then compound 1; then compound 3.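

Replacing 5-methyl-1H-indol-2-yl with 1-cyclopropyl-1H-imidazol-4-yl on the carbonyl carbon gives a 12-fold higher number from compound 2 to compound 3 (1.08 log units; beyond the scatter) in this assay, so this position can move the number much further than the earlier 2.8-fold lower number from compound 1 to compound 2 (0.44 log units; beyond the scatter). The swap alters the ring type, heavy-atom count and hydrogen-bond counts together, so no single feature can be singled out. Nothing available explains the rise. On these data alone, it remains open whether a plain phenyl or 1-methyl-1H-imidazol-4-yl would give a similar number, and whether the step would hold with the (pyrrolidin-2-yl)methyl group of compound 1.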